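The source may report more compounds than this note shows. Statements on the series, on what has been measured and on what is new or still open speak of the compounds shown alone.

Working notes on the series. Of the compounds shown here, three sharing one core have been measured in a functional assay on M21 cells (Homo sapiens) for antiproliferative activity, read by sulforhodamine B assay, with a stated time of 48 h; a higher number here means a weaker inhibitor, a lower number a stronger inhibitor. Compound 1 `CC(C)c1ccccc1OS(=O)(=O)c1cccc(NC(=O)C(C)(C)C)c1` gives 13000 nM. Compound 2 `CC(C)C(=O)Nc1ccc(S(=O)(=O)Oc2ccccc2C(C)C)cc1` gives 11000 nM, the lowest of the three numbers, though within the scatter of both other compounds. Compound 3 `CC(C)C(=O)Nc1ccc(S(=O)(=O)Oc2ccccc2I)cc1` gives 13000 nM. Within the data shown here, the only single-point step among them, a 1.2-fold higher number from compound 2 to compound 3 (0.07 log units; within the scatter), alters a substituent on an aromatic carbon and stays within the scatter, so the series so far shows no change beyond noise.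

Compound 4 `CC(C)c1ccccc1OS(=O)(=O)c1ccc(NC(=O)NC2CCCC2)cc1` has not been measured. It differs from compound 2 by cyclopentylamino in place of isopropyl on a carbonyl carbon. Among the measured compounds shown here, no measured step touches the carbonyl carbon, so nothing in the data speaks directly to this change. For the measured compounds named here, the one step in hand, a 1.2-fold higher number from compound 2 to compound 3 (0.07 log units; within the scatter), was flat, and the three values sit close together, which gives no ground to expect a move beyond the scatter in either direction. The step is therefore estimated as no change at the digits printed from compound 2 to compound 4 (within the scatter). Compound 4 is expected to come in at 11000 nM, with a range from 4500 nM to 27000 nM.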

Compound 4, half-maximal inhibitory concentration: 6100 nM
Estimate against measurement, compound 4: 1.8-fold (0.26 log units) above, within the range that was stated.
By their numbers in this assay, from the lowest: compounds 4, 2, 1 and 3 (each within the scatter of the next, the first and the last beyond it).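

In this assay, among these compounds, cyclopentylamino in place of isopropyl on a carbonyl carbon gives a 1.8-fold lower number from compound 2 to compound 4 (0.26 log units; within the scatter), the first reading at this place. The change turns (isopropylcarbonyl)amino into (cyclopentylcarbamoyl)amino, bringing in a five-membered ring of carbon and a hydrogen-bond donor, and this place accepts both without a shift beyond the scatter. No measured property of these compounds bears on this step.

Since the ring and the added nitrogen enter together, their separate contributions remain unresolved; cyclopentyl bonded directly to the carbonyl carbon and isopropylamino at the same place would pull them apart. Also open, from the compounds shown here alone, is how this place responds to groups of another kind, such as a carboxylic acid, a tertiary amine or a longer alkyl chain.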